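Imidazolyl for cyano on the shared quinoline-type core

This account rests on a few compounds, and the source may have more. Where it says the series, first, only, none or still open, it means among the compounds named here.

Working notes on the series. Compound 1 `C[C@H](Oc1ccc(NC(=O)CC(N)=O)c(C2CC2)c1)c1c(Cl)ccc(F)c1Cl` gives 3.9 in a physicochemical assay for lipophilicity, using the shake flask method; on this read-out lower numbers stand for lower lipophilicity and higher numbers for higher lipophilicity. Among the measured compounds shown here, compound 2 `C[C@H](Oc1ccc2ncc(/C=C/C(=O)O)c(C#N)c2c1)c1c(Cl)ccc(F)c1Cl` gives 2.3 in this assay, the lowest of the two numbers so far and, against compound 1, a gap beyond the scatter. Compound 3 `C[C@H](Oc1ccc2ncc(/C=C/C(=O)O)c(-n3ccnc3)c2c1)c1c(Cl)ccc(F)c1Cl` is the next member, not yet measured. It differs from compound 2 in one place: 1H-imidazol-1-yl in place of cyano on an aromatic carbon. For the measured compounds named here, no step between measured compounds covers such a change, so the expectation leans on compound 2 alone. The step is expected to be small, at most slightly upward, a number 0.20 log units higher from compound 2 to compound 3 (within the scatter). For compound 3 the estimate is 2.5, within 2 to 3.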

Compound 3, distribution coefficient: 2
Compound 3: the middle estimate sits 0.50 log units above what was measured; low and high end bracket the measured number.
By their numbers in this assay, from the lowest: compounds 3 and 2 (each within the scatter of the next); then compound 1.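

In this assay, 1H-imidazol-1-yl in place of cyano on this aromatic carbon, ortho to the 2-carboxyethenyl group and opposite the ring nitrogen, gives a number 0.30 log units lower from compound 2 to compound 3 (within the scatter) on the shared core. A five-membered aromatic ring with 2 hetero atoms can thus enter here with the read-out staying within the scatter of the cyano compound. Nothing measured on these compounds accounts for this result.

Open, going by these compounds, is how an amine or a methoxy group at this position would read in this assay. Also open, on these data alone, is whether the same replacement gives a similar step with a longer chain in place of the 2-carboxyethenyl group.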